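Three Aromatic Groups on a Shared Core

This account rests on a few compounds, and the source may have more. Where it says the series, first, only, none or still open, it means among the compounds named here.

Compound 1 `CC(C)(C)Cc1c(-c2ccncc2)sc(N)c1C(=O)c1ccc(Cl)cc1` and compound 2 `Cc1ccccc1-c1sc(N)c(C(=O)c2ccc(Cl)cc2)c1CC(C)(C)C` share one core and differ only in the aromatic group attached to an aromatic carbon of it. In an assay on CHO cells for displacement of a labelled ligand from adenosine receptor A1 (Homo sapiens), read by scintillation counting, tested at 10 uM (on this read-out higher numbers stand for more inhibition at the one concentration tested (going by the name of the read-out) and lower numbers for less inhibition), compound 1 gives 1%. In this assay compound 2 gives 1%. The step of no change at the digits printed from compound 1 to compound 2 (within the scatter) shows that putting 2-methylphenyl in place of pyridin-4-yl left the read-out unmoved, so compound 2 stands level with compound 1, and neither shows inhibition beyond the scatter. Compound 3 `CC(C)(C)Cc1c(-c2ccsc2)sc(N)c1C(=O)c1ccc(Cl)cc1` has not yet been measured; it differs from compound 2 as follows: thiophen-3-yl in place of 2-methylphenyl on an aromatic carbon. Among the compounds with values here, the only measured step that bears on this change is the exchange of the aromatic group on an aromatic carbon between compound 1 and compound 2, which stayed within the scatter, and a further exchange of that group is therefore expected to give no movement beyond the scatter, a number 1 percentage points higher from compound 2 to compound 3 (within the scatter). Compound 3 is expected to give 2% in this assay, within a range from -8% to 12%.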

Compound 3, a percentage reported as inhibition, at one concentration (the size of the read-out at that concentration, not a potency): 2%
The estimate for compound 3 equals the measured number at the digits printed, and the stated range covers the measured number.
By their numbers in this assay, from the lowest: compounds 1, 2 and 3 (each within the scatter of the next).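

In this assay, thiophen-3-yl on the aromatic carbon next to the ring sulfur gives a number 1 percentage points higher from compound 2 to compound 3 (within the scatter) and, set against the pyridin-4-yl of the first compound, a number 1 percentage points higher from compound 1 to compound 3 (within the scatter). The earlier compounds shown here carried only six-membered aromatic rings at this position, so the result adds a five-membered aromatic ring with 1 hetero atom, a group of 5 heavy atoms in place of 7, and the read-out still stays within the scatter across all three groups. No measurement at hand gives a reason for this flat result.

The compounds shown leave open whether a non-aromatic group at this position, such as a morpholine ring, a primary amine or a carboxylic acid, would move the read-out beyond the scatter. They also leave open whether a change elsewhere on the shared core, such as a longer chain in place of the neopentyl group, would do so.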